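This account rests on a few compounds, and the source may have more. Where it says the series, first, only, none or still open, it means among the compounds named here.

Of the compounds shown here, three built on one shared core have been tested in an assay on CHO cells for agonist activity at 5-hydroxytryptamine receptor 1D (Homo sapiens), read by GTPgammaS binding; on this read-out lower numbers stand for an effect already at smaller amounts and higher numbers for an effect only at larger amounts of compound. Compound 1 `O[C@@H]1Cc2ccccc2[C@H]1NC1CCN(CCCc2c[nH]c3ccc(-n4cnnc4)cc23)CC1` gives 13 nM. Compound 2 `c1ccc2c(c1)CCC2NC1CCN(CCCc2c[nH]c3ccc(-n4cnnc4)cc23)CC1` gives 25 nM. Compound 3 `c1ccc(CNC2CCN(CCCc3c[nH]c4ccc(-n5cnnc5)cc34)CC2)cc1` gives 7.6 nM. Compound 3 and compound 1 lie within the usual scatter of each other, as the step of a 1.7-fold lower number from compound 1 to compound 3 (0.23 log units; within the scatter) shows, while compound 2 stands apart beyond the scatter, as the step of a 3.3-fold lower number from compound 2 to compound 3 (0.52 log units; beyond the scatter) shows.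

Compound 4 `C[C@@H](NC1CCN(CCCc2c[nH]c3ccc(-n4cnnc4)cc23)CC1)c1ccccc1` differs from compound 3 by methyl in place of hydrogen on a saturated chain carbon bound to an amine nitrogen and an aromatic carbon. Within the data shown here, the steps that bear on this change are those that alter the same group on the amine nitrogen: a 1.7-fold lower number from compound 1 to compound 3 (0.23 log units; within the scatter) and a 3.3-fold lower number from compound 2 to compound 3 (0.52 log units; beyond the scatter), with a 1.9-fold higher number from compound 1 to compound 2 (0.28 log units; within the scatter) between the groups of compounds 1 and 2. Those exchanges swapped the entire group for a different one and still moved the number only modestly or within the scatter; adding a single methyl is a smaller change, and the new group sits between benzyl and the groups of compounds 1 and 2. A step no larger than modest is therefore expected, if any, toward a somewhat higher number, and it is estimated as a 1.6-fold higher number from compound 3 to compound 4 (0.20 log units; within the scatter). Compound 4 is expected to give about 12 nM in this assay, within a range from 5 nM to 30 nM.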

Compound 4, half-maximal effective concentration: 13 nM
Compound 4: the middle estimate sits 1.1-fold (0.03 log units) below what was measured; the measured number falls inside the stated range.
By their numbers in this assay, from the lowest: compounds 3, 1, 4 and 2 (each within the scatter of the next, the first and the last beyond it).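

In this assay, methyl in place of hydrogen on the saturated chain carbon bound to an amine nitrogen and an aromatic carbon gives a 1.7-fold higher number from compound 3 to compound 4 (0.23 log units; within the scatter), so this position takes a methyl without a step beyond the scatter. The 1-phenylethyl group on the amine nitrogen also stays within the scatter of the two 2,3-dihydro-1H-inden-1-yl groups, with a 1.9-fold lower number from compound 2 to compound 4 (0.28 log units; within the scatter) and no change at the digits printed from compound 1 to compound 4 (within the scatter), which places compound 4 within the scatter of all three earlier compounds, even though compound 2 and compound 3 lie beyond the scatter of each other. Nothing measured here offers an explanation for these numbers.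

The compounds shown cover only hydrogen and methyl on this carbon, so they leave open whether a larger or differently built group there, such as ethyl, hydroxymethyl, an amine or a carboxylic acid, would keep the number in the same region. They also leave open how the mirror-image arrangement of the methyl in compound 4 would read in this assay.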